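Chloro on the pendant phenyl of the pyrrolidinyl analogue

The source may report more compounds than this note shows. Statements on the series, on what has been measured and on what is new or still open speak of the compounds shown alone.

In a functional assay on NCI-H460 cells (Homo sapiens) for cytotoxicity, read by MTT assay, with a stated time of 72 h (a higher number here means a weaker inhibitor, a lower number a stronger inhibitor), compound 1 `COc1cc2c(Oc3ccc(NC(=O)c4cc(-c5ccccc5)nc5ccc(F)cc45)cc3F)ccnc2cc1OCCCN1CCCCC1` gives 32 nM, compound 2 `COc1cc2c(Oc3ccc(NC(=O)c4cc(-c5cccc(Cl)c5)nc5ccc(F)cc45)cc3F)ccnc2cc1OCCCN1CCC(C)CC1` gives 60 nM, and compound 3 `COc1cc2c(Oc3ccc(NC(=O)c4cc(-c5ccccc5)nc5ccc(F)cc45)cc3F)ccnc2cc1OCCCN1CCCC1` gives 90 nM. Within the data shown here, compound 3 has the highest number of the three measured so far; its gap to compound 2 is within the scatter, while the step of a 2.8-fold higher number from compound 1 to compound 3 (0.45 log units; beyond the scatter) is beyond it.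

Compound 4 `COc1cc2c(Oc3ccc(NC(=O)c4cc(-c5cccc(Cl)c5)nc5ccc(F)cc45)cc3F)ccnc2cc1OCCCN1CCCC1` is compound 3 with one change: chloro in place of hydrogen on an aromatic carbon. Expressed one bond further out, the pendant phenyl becomes a 3-chlorophenyl. Among the measured compounds shown here, no measured pair differs in this change alone. Compound 2 carries the same chloro but also a different amine at the end of the chain, so its number against that of compound 3 mixes two changes; all that can be said is that compound 2 gives 60 nM and compound 3 gives 90 nM, a difference within the scatter. For the measured compounds named here, the only single step measured, the amine change from compound 1 to compound 3, concerns a different site.

With nothing direct to lean on, the expectation for compound 4 is a step of no more than the scatter in this assay, a 1.1-fold lower number from compound 3 to compound 4 (0.05 log units; within the scatter), in no settled direction. Compound 4 is accordingly estimated at 80 nM, with a range from 35 nM to 180 nM.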

Compound 4, half-maximal inhibitory concentration: 72 nM
Beside the measured number, compound 4's estimate is 1.1-fold (0.05 log units) above it, within the range that was stated.
By their numbers in this assay, from the lowest: compounds 1, 2, 4 and 3 (each within the scatter of the next, the first and the last beyond it).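

In this assay, chloro in place of hydrogen on an aromatic carbon can now be read on its own, and the phenyl to 3-chlorophenyl change gives a 1.3-fold lower number from compound 3 to compound 4 (0.10 log units; within the scatter) with pyrrolidin-1-yl at the end of the chain, so no effect of the chloro can be separated from the scatter in this pair. With 3-chlorophenyl held fixed, pyrrolidin-1-yl in place of 4-methylpiperidin-1-yl gives a 1.2-fold higher number from compound 2 to compound 4 (0.08 log units; within the scatter) and also stays within the scatter, while the earlier step on the unsubstituted phenyl, a 2.8-fold higher number from compound 1 to compound 3 (0.45 log units; beyond the scatter), started from piperidin-1-yl, so the two amine steps do not compare the same pair of amines. No evidence beyond these cell numbers bears on either result, and the reading stops at the numbers themselves.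

Going by these compounds, whether chloro gives a similarly small step with piperidin-1-yl at the end of the chain remains open. Also open, on these data alone, is how a methoxy or trifluoromethyl group on the pendant phenyl, or a morpholine in place of the pyrrolidine, would read in this assay.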